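Swapping the Aromatic Amide Cap on a Sulfamoyl Urea

A few compounds are considered here, and "the series" means these few. Any claim that something is new, unique, unknown or untested is made for them only; others in the source may bear on it.

Compound 2 `O=C(NC[C@@H]1C[C@@H]2C=C[C@@H]1C2)NS(=O)(=O)N1CCC(CCNC(=O)c2nc3ccccc3s2)CC1` and compound 1 `O=C(NC[C@@H]1C[C@@H]2C=C[C@@H]1C2)NS(=O)(=O)N1CCC(CCNC(=O)C(F)(F)F)CC1` share one core and differ only in the group attached to the carbonyl carbon at the end of the side chain. In a functional assay on the whole organism (blood) with Rattus norvegicus as the target, with stated times of 24 h and 1 h, at a dose of 5 mg/kg by the intraperitoneal route (on this read-out higher numbers stand for a stronger effect at the one dose given and lower numbers for a weaker effect), compound 2 gives 24%, and compound 1 gives 22%; these two numbers lie within the scatter of each other, so neither compound can be called stronger. Going by the values given here, the step of a number 2 percentage points higher from compound 1 to compound 2 (within the scatter) is the only measured change at this position, and it did not move the read-out beyond the scatter. Compound 3 `O=C(NC[C@@H]1C[C@@H]2C=C[C@@H]1C2)NS(=O)(=O)N1CCC(CCNC(=O)c2cccc3c2OCCO3)CC1` changes the same place once more: 2,3-dihydro-1,4-benzodioxin-5-yl in place of 1,3-benzothiazol-2-yl on a carbonyl carbon. Among the compounds with values here, with a single within-scatter step as the sole guide, no shift beyond the scatter is expected in this assay for compound 3, an estimated step of a number 1 percentage points lower from compound 2 to compound 3 (within the scatter). Compound 3 is therefore expected to give about 23%, between 10% and 38%.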

Compound 3, a percentage reported as activity, at one dose (the size of the read-out at that dose, not a potency): 11%
The estimate for compound 3 lay 12 percentage points above the measured number, within the range that was stated.
By their numbers in this assay, from the lowest: compound 3; then compounds 1 and 2 (each within the scatter of the next).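

In this assay the group on the carbonyl carbon now proves able to move the read-out: 2,3-dihydro-1,4-benzodioxin-5-yl in place of 1,3-benzothiazol-2-yl gives a number 13 percentage points lower from compound 2 to compound 3 (beyond the scatter) and, set against trifluoromethyl, the same group gives a number 11 percentage points lower from compound 1 to compound 3 (beyond the scatter) at this one dose. Compound 1 and compound 2 stood within the scatter of each other and gave no sign of this, so a change of cap at this position is not always without effect. No measurement at hand explains why this group behaves differently from the other two.

Still open, going by these compounds, is whether the loss follows from the oxygen-containing non-aromatic ring or from the attachment of the aromatic ring to the carbonyl carbon. A plain phenyl group at the same place would help to separate these two readings.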